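Alkoxyphenyl Variation on the Amine of a Shared Core

A few compounds are considered here, and "the series" means these few. Any claim that something is new, unique, unknown or untested is made for them only; others in the source may bear on it.

Compound 1, `COc1ccccc1Nc1nc(SCc2ccc(C(F)(F)F)cc2)nc2ccccc12`, reaches only a limit of the assay in a functional assay on MCF7 cells (Homo sapiens) for cytotoxicity, read by MTT assay, with a stated time of 72 h (on this read-out lower numbers stand for stronger inhibition and higher numbers for weaker inhibition), reported as > 50000 nM.
Compound 2, `FC(F)(F)c1ccc(CSc2nc(Nc3cccc(Cl)c3)c3ccccc3n2)cc1`, gives 25100 nM in this assay.
Compound 3, `CCOc1ccc(Nc2nc(SCc3ccc(C(F)(F)F)cc3)nc3ccccc23)cc1`, likewise stops at a limit in this assay, reported as > 50000 nM.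

Compound 3 thus stands at the upper edge of what this assay can report, and it is not alone there: the limit of > 50000 nM in this assay, at which 2 of the 3 values shown sit. Only compound 2 gives a number, so compound 3 can be placed relative to the others only by limits.

Compound 4, `COc1ccc(Nc2nc(SCc3ccc(C(F)(F)F)cc3)nc3ccccc23)cc1OC`, differs from compound 3 in one place: 3,4-dimethoxyphenyl in place of 4-ethoxyphenyl on a nitrogen on an aromatic ring. The measured steps that bear on this change are those at the same nitrogen. Going to the chloro-bearing aryl gave an at least 1.9-fold lower number from compound 1 to compound 2 (0.29 log units; that floor lies within the scatter), while returning to an alkoxy-bearing aryl gave an at least 1.9-fold higher number from compound 2 to compound 3 (0.29 log units; that floor lies within the scatter); between the two alkoxy-bearing aryls the limits leave the step unreadable, a step that the two limits leave unreadable from compound 1 to compound 3. Among the measured compounds both alkoxy-bearing aryls sit at the limit, and compound 4 carries two methoxy groups on its aryl. The step of a number no higher from compound 3 to compound 4 (the limit leaves the size open) is therefore expected to show nothing beyond the scatter, with a real chance that only a limit is reported again. Compound 4 is estimated at 50000 nM, within 20000 nM to 120000 nM.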

Compound 4, half-maximal inhibitory concentration: > 50000 nM
Compound 4 was reported as a limit; the forecaster's own chance of this, stated with the estimate: 65%; the middle value sits exactly at the limit.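

Compound 4 adds the 3,4-dimethoxyphenyl group as a third alkoxy-bearing aryl on this nitrogen, and like the 2-methoxyphenyl and 4-ethoxyphenyl groups it yields no number in this assay, so every alkoxy-bearing aryl shown now ends at the same edge, with the 3-chlorophenyl of compound 2 as the only exception: the limit of > 50000 nM in this assay, at which 3 of the 4 values shown sit.

Going by these compounds alone, the only readable new step is an at least 1.9-fold higher number from compound 2 to compound 4 (0.29 log units; that floor lies within the scatter), so this floor alone does not establish a gap beyond the scatter between the 3-chlorophenyl and 3,4-dimethoxyphenyl groups. The steps that join compound 4 to compound 3 and to compound 1 run from limit to limit and cannot be read.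

The compounds shown leave open how far compound 1, compound 3 and compound 4 lie past the limit, and therefore whether these alkoxy-bearing aryls differ from one another at all. They also leave open how an aryl carrying an amine or a carboxylic acid, or a longer alkoxy chain, would read at this nitrogen in this assay.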